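The source may hold more compounds than are shown below. What is called first, only, known or untested is meant among the compounds shown, and "the series" means these compounds.

Working notes on the series, read in a functional assay on cells (Panel (Carcinoma cell lines), Homo sapiens) for inhibition; a higher number here means a weaker inhibitor of growth, a lower number a stronger inhibitor of growth. Compound 1 `COc1ccc(C23OCC24C(CO)C4Cc2cc(OC)c(OC)cc23)cc1OC` gives > 100000 nM, which is a limit of the assay and not a number. Compound 2 `COc1ccc(C23OCC24C2COC(c5cc(OC)c(OC)cc53)C24)cc1OC` gives > 100000 nM, again only a limit. Compound 2 therefore has no numerical position in the series, and the whole picture so far is the limit of > 100000 nM in this assay, at which 2 of the 2 values shown sit.

Compound 3 `COc1cc2c(cc1OC)C1(c3cc(OC)c(OC)c(OC)c3)OCC13C1COC2C13` differs from compound 2 at one place: methoxy in place of hydrogen on an aromatic carbon. In words, this is methoxy in place of hydrogen on an aromatic carbon, ortho to a methoxy group and meta to a large group. Going by the values given here, no measured pair shows what such a change does, so its size has to be judged without a precedent. Neither measured compound gives a growth inhibition value to build on, and a further report of a limit is the likeliest outcome. In this assay no change beyond the scatter is expected, and the estimated step is a number no higher from compound 2 to compound 3 (the limit leaves the size open). For compound 3 the estimated value is 100000 nM, with an expected range of 30000 nM to 300000 nM.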

Compound 3, concentration for 50% growth inhibition: 41700 nM
Compound 3: middle estimate off by 2.4-fold (0.38 log units), on the high side; the range from low to high includes it.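

Methoxy in place of hydrogen on an aromatic carbon, ortho to a methoxy group and meta to a large group, gives an at least 2.3-fold lower number from compound 2 to compound 3 (0.37 log units; beyond the scatter) in this assay. Going by these compounds alone, this is the first change with a visible effect on growth inhibition, and it shows that this position on the ring can respond to substitution, with compound 3 giving 41700 nM, a real number. The true size of the step remains unknown because compound 2 has only a limit as its reading, so the step is a minimum and not a measured difference: the limit of > 100000 nM in this assay, at which 2 of the 3 values shown sit.

From the compounds shown here alone, this rests on a single pair, so it stays open whether the effect belongs to methoxy itself or would also appear with a hydroxyl group, an amine, a halogen such as fluorine or a longer chain such as ethoxy at the same position. Going by these compounds, it is equally open whether the same methoxy would act in the same way on a different core, such as that of compound 1, or whether further substitution on this ring would move the number any lower.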